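Vinyl amide replacing chloropropyl amide in a phenylpentanol series

The source may hold more compounds than are shown below. What is called first, only, known or untested is meant among the compounds shown, and "the series" means these compounds.

Compound 1 `CCCCC(O)c1cccc(NC(=O)NCCCCl)c1`: 35000 nM
Compound 2 `CCCCC(O)c1cccc(NC(=O)CCCCl)c1`: > 100000 nM

In a functional assay on M21 cells (Homo sapiens) for antiproliferative activity, with a stated time of 48 h (a lower number here means a stronger inhibitor, a higher number a weaker inhibitor), compound 2 gives > 100000 nM, which is a limit of the assay and not a number. Compound 1 in this assay gives 35000 nM. Among the measured compounds shown here, the one measured step is an at least 2.8-fold higher number from compound 1 to compound 2 (0.45 log units; beyond the scatter), a change of the link to the carbonyl, and it stands at the limit of > 100000 nM in this assay, at which 1 of the 2 values shown sits.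

Compound 3 `C=CC(=O)Nc1cccc(C(O)CCCC)c1` differs from compound 2 by vinyl in place of 3-chloropropyl on a carbonyl carbon. The measured step does not touch the chain on the carbonyl carbon, so its size gives no guide to this change; the step of an at least 1.6-fold lower number from compound 2 to compound 3 (0.22 log units; that floor lies within the scatter) is therefore an expectation without a measured counterpart. The estimate for compound 3 in this assay is 60000 nM, expected to lie between 10000 nM and 300000 nM.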

Compound 3, half-maximal inhibitory concentration: 98000 nM
Compound 3: the middle estimate sits 1.6-fold (0.21 log units) below what was measured, and the stated range covers the measured number.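

In this assay, among the compounds shown here, vinyl in place of (3-chloropropyl)amino on a carbonyl carbon gives a 2.8-fold higher number from compound 1 to compound 3 (0.45 log units; beyond the scatter), the first step at this position that rests on two numbers. The step to vinyl from 3-chloropropyl reads only as a floor, an at least 1.0-fold lower number from compound 2 to compound 3 (0.00 log units; that floor lies within the scatter), so these two groups cannot be ordered. Compound 2 stands at a limit of the assay, not a number: the limit of > 100000 nM in this assay, at which 1 of the 3 values shown sits.

Open, as far as these compounds go, is whether a shorter or longer chain on the amino nitrogen would lower the number further. Also open, from the compounds shown here alone, is how a vinylamino group or a 3-aminopropyl group on the carbonyl carbon would read.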